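A few compounds are considered here, and "the series" means these few. Any claim that something is new, unique, unknown or untested is made for them only; others in the source may bear on it.

Working notes on the series in a functional assay on A549 cells (Homo sapiens) for cytotoxicity, read by XTT assay, with a stated time of 72 h; a lower number here means a stronger inhibitor, a higher number a weaker inhibitor. Compound 1 (`C=C1CC[C@H]2C(C)(C)CCC[C@]2(C)[C@H]1CC/C(C)=C/COc1cc(O)c2c(=O)c(O)c(-c3ccc(OC)cc3)oc2c1`) gives > 100000 nM, which is a limit of the assay and not a number. Compound 2 (`CCCCCCCCCCCCCCCCCCOc1cc(O)cc(O)c1C(C)=O`) gives > 100000 nM, also a limit. For the measured compounds named here, compound 3 (`CC(=O)c1c(O)cc(O)c(CC=C(C)C)c1O`) gives 29000 nM, the one true number so far. On these data alone, compound 1 therefore stands at the limit of > 100000 nM in this assay, at which 2 of the 3 values shown sit, and how far its real value lies past that limit is unknown.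

Next in line is compound 4 (`C=C1CC[C@H]2C(C)(C)CCC[C@]2(C)[C@H]1CC/C(C)=C/COc1cc(O)c2c(=O)c(O)c(-c3ccc(O)cc3)oc2c1`), which keeps the core of compound 1 and changes in one place: hydrogen in place of methyl on an oxygen on an aromatic ring. This puts hydrogen in place of methyl on an oxygen on an aromatic ring, turning methoxy to hydroxy and 4-methoxyphenyl to 4-hydroxyphenyl. Going by the values given here, no measured pair differs in one place, so the series gives no direct size for such a change. A modest move in this assay toward stronger inhibition is expected, and a result again at the limit would be no surprise. The estimate amounts to an expected at least 1.6-fold lower number from compound 1 to compound 4 (0.22 log units; that floor lies within the scatter). Among the compounds with values here, the only number available as an anchor is that of compound 3, which gives 29000 nM. For compound 4 the estimated value is 60000 nM, with an expected range from 20000 nM to 150000 nM.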

Compound 4, half-maximal inhibitory concentration: > 100000 nM
Compound 4 was reported as a limit (the forecaster's own chance of this, stated with the estimate: 55%); middle value at least 1.6-fold (0.22 log units) away from the limit.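

In this assay compound 4 gives > 100000 nM, which is a limit of the assay and not a number. For the compounds shown here, compound 1 is also a limit, so no step between compound 1 and compound 4 can be read. The compounds shown leave open whether hydrogen in place of methyl on an oxygen on an aromatic ring shifts the real value at all, with most of the series sitting here: the limit of > 100000 nM in this assay, at which 3 of the 4 values shown sit.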